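From Compound 3 to Compound 4: Ethyl for 3-Methoxyphenyl

The source may hold more compounds than are shown below. What is called first, only, known or untested is meant among the compounds shown, and "the series" means these compounds.

Three compounds have been measured in a functional assay on B16-F10 cells (Mus musculus) for antiproliferative activity, read by MTT assay, with a stated time of 48 h; a lower number here means a stronger inhibitor, a higher number a weaker inhibitor:
Compound 1, `O=C(/C=C/c1ccc(O)c(O)c1)N1CCN(c2ccccc2F)CC1`, gives 2.43 ug/mL.
Compound 2, `COc1ccccc1N1CCN(C(=O)/C=C/c2ccc(O)c(O)c2)CC1`, gives 1.23 ug/mL.
Compound 3, `COc1cccc(N2CCN(C(=O)/C=C/c3ccc(O)c(O)c3)CC2)c1`, gives 1.46 ug/mL.

Compound 3 stands second highest of the three numbers. Its nearest neighbour is compound 2, with a 1.2-fold higher number from compound 2 to compound 3 (0.07 log units; within the scatter), and its furthest is compound 1, with a 1.7-fold lower number from compound 1 to compound 3 (0.22 log units; within the scatter). The remaining step, a 2.0-fold lower number from compound 1 to compound 2 (0.30 log units; within the scatter), is likewise within the scatter, so the three measured compounds cannot be separated from one another on these numbers.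

Compound 4, `CCN1CCN(C(=O)/C=C/c2ccc(O)c(O)c2)CC1`, differs from compound 3 in one place: ethyl in place of 3-methoxyphenyl on an amine nitrogen in a ring. Among the measured compounds shown here, none of the measured steps bears directly on this kind of change. All three exchange one substituted phenyl on the ring nitrogen for another, and none removes the aromatic ring from that nitrogen. They show only that the choice among 2-fluorophenyl, 2-methoxyphenyl and 3-methoxyphenyl does not move this assay beyond the scatter. For the measured compounds named here, the step to an ethyl group therefore has no measured precedent, and its direction is open. The estimate for compound 4 in this assay is 2.5 ug/mL, with a range from 0.9 ug/mL to 8 ug/mL, which means an expected step of a 1.7-fold higher number from compound 3 to compound 4 (0.23 log units; within the scatter) carrying wide uncertainty.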

Compound 4, half-maximal inhibitory concentration: 6.44 ug/mL
Compound 4: the middle estimate sits 2.6-fold (0.41 log units) below what was measured; the measured number falls inside the stated range.
By their numbers in this assay, from the lowest: compounds 2, 3 and 1 (each within the scatter of the next); then compound 4.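

In this assay, the group on the amine nitrogen in the ring proves to matter once the aromatic ring leaves that nitrogen: ethyl in place of 3-methoxyphenyl gives a 4.4-fold higher number from compound 3 to compound 4 (0.64 log units; beyond the scatter), ethyl in place of 2-methoxyphenyl gives a 5.2-fold higher number from compound 2 to compound 4 (0.72 log units; beyond the scatter), and ethyl in place of 2-fluorophenyl gives a 2.7-fold higher number from compound 1 to compound 4 (0.42 log units; beyond the scatter). The three phenyl-bearing compounds could not be separated from one another, yet each now stands apart from compound 4, so this position tolerates the phenyl exchanges shown but responds to this larger change, which replaces a group of 8 heavy atoms with one of 2. Nothing available explains the rise in the number.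

The compounds shown leave open whether the rise goes with the loss of the aromatic ring or with the smaller size of the group, as ethyl differs from the phenyl groups in both ways. A cyclohexyl or benzyl group on that nitrogen, or a longer chain such as butyl, would help to separate these two readings.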